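A few compounds are considered here, and "the series" means these few. Any claim that something is new, unique, unknown or untested is made for them only; others in the source may bear on it.

Working notes on the series, cytotoxicity in a functional assay on HT-29 cells (Homo sapiens) for cytotoxicity, read by MTT assay, with a stated time of 72 h; a lower number here means that less compound is tolerated, a higher number that more compound is tolerated.

Of the compounds shown here, two have numbers so far. Compound 1 `N#C[Se]c1ccc(NC(=O)Oc2ccc(F)cc2)cc1` gives 66500 nM in this assay. Compound 2 `C=CCOC(=O)Nc1ccc([Se]C#N)cc1` gives 72800 nM in this assay. Compound 1 holds the lower of the two numbers, but the gap to compound 2 lies within the scatter of repeated measurements, so the two cannot be ordered against each other: both sit at the same, weakly cytotoxic level on the shared core.

For the measured compounds named here, no pair of measured compounds differs in a single place, so no step of any kind has yet been observed.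

Compound 3 `N#C[Se]c1ccc(NC(=O)Oc2ccc(Cl)cc2)cc1` is the next one to be measured. It differs from compound 1 in a single exchange on the carbamate aryl ring: chloro in place of fluoro on an aromatic carbon. Going by the values given here, with no comparable step on record and the only two known values lying within the scatter of each other, the step from compound 1 to compound 3 is expected to be no larger than the scatter itself, with no direction to favour, giving an expected 1.1-fold lower number from compound 1 to compound 3 (0.04 log units; within the scatter). Compound 3 is therefore estimated at 60000 nM in this assay, with a range from 30000 nM to 120000 nM.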

Compound 3, concentration lethal to 50% of the cells: 68700 nM
Beside the measured number, compound 3's estimate is 1.1-fold (0.06 log units) below it; the range from low to high includes it.
By their numbers in this assay, from the lowest: compounds 1, 3 and 2 (each within the scatter of the next).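

The series now has its first single-place step: in this assay, chloro in place of fluoro on an aromatic carbon, para to a large group, gives a 1.0-fold higher number from compound 1 to compound 3 (0.01 log units; within the scatter) and so stays within the scatter. The earlier compounds shown here could not show this, as they offered no comparison at a single place: at this position of a six-membered aromatic ring of carbon only, fluoro and chloro cannot be told apart in this read-out, and compound 1 and compound 3 stand at the same weakly cytotoxic level. No measured property of either group accompanies this result, so the pair offers no explanation for it.

The compounds shown leave open whether this level holds when the same position carries something other than a halogen, such as a methoxy group, an amine or a carboxylic acid. For the compounds shown here, they also leave open whether fluoro and chloro remain indistinguishable at another place on this ring, since the one step on record covers a single position and a single exchange.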